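This account rests on a few compounds, and the source may have more. Where it says the series, first, only, none or still open, it means among the compounds named here.

Compound 2 `COC(=O)c1ccc2c(ccn2-c2ccc(NC(=O)c3cccc(C(F)(F)F)c3)cc2)n1` is the weaker of the two compounds measured in an ADME assay on HS27 cells (Homo sapiens) for cytotoxicity, read by MTT assay (on this read-out lower numbers stand for stronger inhibition and higher numbers for weaker inhibition), where compound 2 gives 9800 nM. Compound 1 `COC(=O)c1ccc2c(ccn2-c2ccc(NC(=O)c3ccc(Cl)c(C(F)(F)F)c3)cc2)n1` gives 2900 nM, and a 3.4-fold higher number from compound 1 to compound 2 (0.53 log units; beyond the scatter), a change of hydrogen in place of chloro on an aromatic carbon. Compound 3 `O=C(Nc1ccc(-n2ccc3nc(C(=O)NCc4ccccc4)ccc32)cc1)c1cccc(C(F)(F)F)c1` differs from compound 2 by benzylamino in place of methoxy on a carbonyl carbon. Among the measured compounds shown here, no measured step touches this position, so the single known step is not a guide here, and no shift beyond the scatter is expected, with compound 3 estimated at 8000 nM (range 2500 nM to 25000 nM), a step of a 1.2-fold lower number from compound 2 to compound 3 (0.09 log units; within the scatter).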

Compound 3, half-maximal inhibitory concentration: > 10000 nM
Compound 3: only a limit was reported; the forecaster's own chance of this, stated with the estimate: 10%; middle value at least 1.2-fold (0.09 log units) from the limit.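

Compound 3 gives > 10000 nM in this assay, which is a limit and not a number: the limit of > 10000 nM in this assay, at which 1 of the 3 values shown sits. At this newly probed place, on a carbonyl carbon, the change from methoxy to benzylamino gives an at least 1.0-fold higher number from compound 2 to compound 3 (0.00 log units; that floor lies within the scatter), so a real rise cannot be told from scatter. What it does show is that this much larger group, with its added aromatic ring, brings no stronger inhibition.

As far as these compounds go, how far compound 3 lies past the limit stays open. So does how a carboxylic acid or a smaller methylamino at this place would read.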